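The source may hold more compounds than are shown below. What is called first, only, known or untested is meant among the compounds shown, and "the series" means these compounds.

Compound 1 `COc1cc2nc(N3CCN(C(=O)C(C)(C)C)[C@H]4CCCC[C@H]43)nc(N)c2cc1OC` and compound 2 `CCCN(CCC)c1nc(N2CCN(C(=O)c3ccco3)[C@H]3CCCC[C@H]32)nc2cc(OC)c(OC)cc12` share a fused bicyclic amine on the same dimethoxy core, and both were examined in an assay on CHO cells for displacement of a labelled ligand from Alpha-1D adrenergic receptor (Homo sapiens), with a stated time of 30 min; on this read-out higher numbers stand for weaker inhibition and lower numbers for stronger inhibition. Compound 1 gives 6.17 nM, and compound 2 gives 5.13 nM; the two numbers sit within the scatter of each other, so compound 1 stands as the higher of the two figures without any real separation from compound 2. Compound 3 `COc1cc2nc(N3CCN(C(=O)OCc4ccccc4)[C@H]4CCCC[C@H]43)nc(N)c2cc1OC` has not yet been measured in this assay. It differs from compound 1 in one place: benzyloxy in place of tert-butyl on a carbonyl carbon. Among the compounds with values here, no measured pair shows what this exchange does on its own, so the size of the step is an open question. Compound 3 is expected to land close to compound 1, with a step of a 1.1-fold higher number from compound 1 to compound 3 (0.02 log units; within the scatter) that is not expected to exceed the scatter in either direction. Compound 3 is therefore estimated at 6.5 nM, with a range from 2 nM to 20 nM.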

Compound 3, inhibition constant: 3.98 nM
Compound 3: middle estimate off by 1.6-fold (0.21 log units), on the high side; low and high end bracket the measured number.
By their numbers in this assay, from the lowest: compounds 3, 2 and 1 (each within the scatter of the next).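

On the carbonyl carbon whose other neighbour is the amide-type nitrogen in a ring, benzyloxy in place of tert-butyl gives a 1.6-fold lower number from compound 1 to compound 3 (0.19 log units; within the scatter) in this assay. This position therefore carries 8 heavy atoms with a six-membered aromatic ring and a hydrogen-bond acceptor, rather than 4 heavy atoms with neither, without a step beyond the scatter, which compounds 1 and 2 alone, differing in more than one place, could not show. No evidence is available to account for this outcome.

The compounds shown do not separate the contributions of the ring and the oxygen of benzyloxy, which a benzyl group on the same carbonyl carbon would address. They also leave open whether a smaller methoxy group or an amine at this place would stay as close to compound 1.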